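The source may report more compounds than this note shows. Statements on the series, on what has been measured and on what is new or still open speak of the compounds shown alone.

Measured so far:

- In an ADME assay on Vero cells (Chlorocebus sabaeus) for cytotoxicity, read by neutral red uptake, tested at 25 ug/mL (on this read-out higher numbers stand for a weaker effect at the one concentration tested and lower numbers for a stronger effect), compound 1 `O=C1CSC(c2ccc(Cl)cc2)N1CCN1CCCCC1` gives 84%.
- In this assay compound 2 `COc1ccc(C2SCC(=O)N2CCN2CCCCC2)cc1` gives 100%.
- In this assay compound 3 `O=C1CSC(c2ccc(O)cc2)N1CCN1CCCCC1` gives 100%.

Compound 3 stands level with compound 2 at the digits reported, and the two sit together at the top of the three numbers; compound 1 is the one that differs, its value lying below both, as a number 16 percentage points higher from compound 1 to compound 3 (beyond the scatter) shows.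

The next compound is compound 4 `Cc1ccc(C2SCC(=O)N2CCN2CCCCC2)cc1`. It differs from compound 3 by methyl in place of hydroxy on an aromatic carbon.

Going by the values given here, no measured step replaces hydroxy with methyl, so the bearing steps are indirect. The pair no change at the digits printed from compound 2 to compound 3 (within the scatter) shows that exchanging the group on the oxygen at this position left the number unchanged. The pairs a number 16 percentage points higher from compound 1 to compound 2 (beyond the scatter) and a number 16 percentage points higher from compound 1 to compound 3 (beyond the scatter) show that a different group at the same position can shift the number by a modest amount. Among the compounds with values here, a methyl at this position has no measured precedent, so the direction of the step is uncertain; a change of no more than modest size, and plausibly none beyond the scatter, is expected in this assay.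

The expected step for compound 4 is a number 7 percentage points lower from compound 3 to compound 4 (within the scatter). Compound 4 is therefore estimated at 93%, within 78% to 100%.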

Compound 4, a percentage reported as activity, at one concentration (the size of the read-out at that concentration, not a potency): 100%
For compound 4 the middle estimate is 7 percentage points below the measured one; low and high end bracket the measured number.
By their numbers in this assay, from the lowest: compound 1; then compounds 2, 3 and 4 (each within the scatter of the next).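

In this assay, an aromatic carbon para to a large group takes methyl as well as the two oxygen-linked groups: no change at the digits printed from compound 3 to compound 4 (within the scatter) and no change at the digits printed from compound 2 to compound 4 (within the scatter). The hydroxy-to-methyl exchange removes one hydrogen-bond donor and one hydrogen-bond acceptor from this place, yet the read-out stays at the same printed number, so an oxygen at this position is not required for that number among these compounds. Methyl also joins methoxy and hydroxy in standing apart from chloro, a number 16 percentage points higher from compound 1 to compound 4 (beyond the scatter), which leaves compound 1 as the only one of the four beyond the scatter of the others, and no measurement on hand gives a reason for this difference.

From the compounds shown here alone, whether the shift belongs to chloro alone or extends to other halogens such as fluoro or bromo remains open, as does the outcome with an amine or a carboxylic acid at this position. A longer chain such as ethyl or propyl in place of methyl is also untested in these notes, and a read-out at one concentration gives no potency for any of the four compounds.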